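Nitro in place of bromo on compound 2

The source may hold more compounds than are shown below. What is called first, only, known or untested is meant among the compounds shown, and "the series" means these compounds.

In a functional assay on MCF7 cells (Homo sapiens) for antiproliferative activity, read by MTT assay, with a stated time of 72 h (on this read-out higher numbers stand for weaker inhibition and lower numbers for stronger inhibition), compound 2 `O=C(N/N=C/c1cccc(Br)c1)Nc1ccc(Oc2ccnc3[nH]ccc23)c(F)c1` reads 49 nM and is the lowest of the three numbers, with compound 3 `O=C(N/N=C/c1ccc(Br)cc1)Nc1ccc(Oc2ccnc3[nH]ccc23)c(F)c1` at 930 nM and compound 1 `O=C(N/N=C/c1ccccc1)Nc1ccc(Oc2ccnc3[nH]ccc23)c(F)c1` at 2380 nM above it. Compound 4 `O=C(N/N=C/c1cccc([N+](=O)[O-])c1)Nc1ccc(Oc2ccnc3[nH]ccc23)c(F)c1` carries nitro in place of bromo on an aromatic carbon, meta to a large group. Bromo in place of hydrogen gave a large step (a 49-fold lower number from compound 1 to compound 2 (1.69 log units; beyond the scatter)) in one case and a modest one (a 2.6-fold lower number from compound 1 to compound 3 (0.41 log units; beyond the scatter)) in the other. 4-bromophenyl in place of 3-bromophenyl gave a large step upward (a 19-fold higher number from compound 2 to compound 3 (1.28 log units; beyond the scatter)). Going by the values given here, no measured step tests nitro, but the place stays the same. In this assay a modest rise is therefore expected (a 2.4-fold higher number from compound 2 to compound 4 (0.39 log units; beyond the scatter)) rather than a large one. Compound 4 is estimated at 120 nM (expected range 30 nM to 500 nM).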

Compound 4, half-maximal inhibitory concentration: "not active" (no number reported)
The entry for compound 4 holds no number, so the estimate cannot be set against anything.
By their numbers in this assay, from the lowest: compound 2; then compound 3; then compound 1.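

In this assay, going by these compounds alone, compound 4 is recorded as "not active" without a number, so no step from compound 2 to compound 4 can be read. Nothing shown bears on that entry. The compounds shown leave open how far nitro in place of bromo shifts the number.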